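Dropping the chloro from a weakly active amide series

This account rests on a few compounds, and the source may have more. Where it says the series, first, only, none or still open, it means among the compounds named here.

Compound 1 `O=C(Nc1cc(C(F)(F)F)ccc1N1CCCC1)c1cccnc1Cl` was tested in a functional assay on HL-60 cells (Homo sapiens) for cytotoxicity, read by MTT assay, with a stated time of 48 h; on this read-out higher numbers stand for weaker inhibition and lower numbers for stronger inhibition. In this assay compound 1 gives "not active" (no number reported), so no single number stands behind it, only the report that nothing measurable was seen. Its close relative compound 2 `O=C(Nc1cc(C(F)(F)F)ccc1N1CCCCC1)c1cccnc1Cl`, which carries a larger saturated ring on the aniline side, gives "not active" (no number reported) in this assay. For the measured compounds named here, the only compound of the set with a number is compound 3 `O=C(Nc1cc(C(F)(F)F)ccc1NC1CCCCC1)c1ccncc1`, whose amide is built on a pyridine with the nitrogen in a different position; in this assay compound 3 gives 59200 nM, a very weak effect. Compound 1 therefore stands among compounds that show little or no inhibition of these cells.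

Compound 4 `O=C(Nc1cc(C(F)(F)F)ccc1N1CCCC1)c1cccnc1` differs from compound 1 in one place: hydrogen in place of chloro on an aromatic carbon. In plain words, hydrogen replaces chloro on an aromatic carbon, so the change is the loss of a single chlorine from the pyridine ring that carries the amide.

Going by the values given here, no measured pair shows what this change does in this assay. With every neighbour of compound 1 sitting at or beyond the weak end, no step beyond the usual scatter is expected in either direction, and a report of no activity remains likely. Compound 4 is estimated to give 70000 nM, with a range from 20000 nM to 200000 nM.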

Compound 4, half-maximal inhibitory concentration: "not active" (no number reported)
Compound 4 has no reported number here, so the estimate cannot be set against anything.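

In this assay compound 1 and compound 4 both stand without a number, so no step can be read from the swap of chloro for hydrogen. No supporting measurement bears on this result. The compounds shown leave open whether losing the chloro changes the effect on these cells at all.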